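The source may hold more compounds than are shown below. What is called first, only, known or untested is meant among the compounds shown, and "the series" means these compounds.

Working notes on the series. In a functional assay on HeLa cells (Homo sapiens) for inhibition, read by cell counting, with a stated time of 96 h (a higher number here means a weaker inhibitor, a lower number a stronger inhibitor), compound 1 `CCN(CC)CN1C(=O)/C(=N/NC(=S)Nc2ccc(OC)cc2)c2ccccc21` gives 4400 nM, the lower of the two true numbers. Compound 2 `CCN(CC)CN1C(=O)/C(=N/NC(=S)Nc2ccc(OC)cc2)c2cc(Cl)ccc21` gives 9200 nM, a modest step: a 2.1-fold higher number from compound 1 to compound 2 (0.32 log units; beyond the scatter). Compound 3 `CCN(CC)CN1C(=O)/C(=N/NC(=S)Nc2ccc(Cl)cc2)c2cc(Cl)ccc21` gives > 125000 nM, which is a limit. Chloro in place of methoxy is a large step: an at least 13-fold higher number from compound 2 to compound 3 (1.13 log units; beyond the scatter).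

Compound 4 `CCN(CC)CN1C(=O)/C(=N/NC(N)=S)c2ccccc21` differs from compound 1 by hydrogen in place of 4-methoxyphenyl on an amide-type nitrogen. For the measured compounds named here, no measured step removes this whole group. The only one that alters it is an at least 13-fold higher number from compound 2 to compound 3 (1.13 log units; beyond the scatter), and a 2.1-fold higher number from compound 1 to compound 2 (0.32 log units; beyond the scatter) concerns another site. A clear weakening is therefore expected in this assay, though its size is uncertain. The expected step is a 6.8-fold higher number from compound 1 to compound 4 (0.83 log units; beyond the scatter). Compound 4 is estimated at 30000 nM, with an expected range of 7000 nM to 125000 nM.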

Compound 4, half-maximal inhibitory concentration: 123000 nM
Beside the measured number, compound 4's estimate is 4.1-fold (0.61 log units) below it; the measured number falls inside the stated range.
By their numbers in this assay, from the lowest: compound 1; then compound 2; then compound 4. At a limit, above all of these: compound 3.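

Hydrogen in place of 4-methoxyphenyl on the amide-type nitrogen gives a 28-fold higher number from compound 1 to compound 4 (1.45 log units; beyond the scatter) in this assay. The earlier steps shown here altered only the ring's substituent or the shared core, whereas this one shows that the compound 1 number depends on the whole aryl group on this nitrogen. Compound 4 keeps a true number close to the ceiling that compound 3 reaches as a limit: the limit of > 125000 nM in this assay, at which 1 of the 4 values shown sits.

The compounds shown leave open whether a plain phenyl or a methyl on this nitrogen would retain the number of compound 1. From the compounds shown here alone, whether a longer chain, such as benzyl, would do so also remains open.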